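A few compounds are considered here, and "the series" means these few. Any claim that something is new, unique, unknown or untested is made for them only; others in the source may bear on it.

Measured in an assay on SH-EP1 cells for agonist activity at Neuronal acetylcholine receptor; alpha4/beta2 (Homo sapiens), read by FLIPR and calcium flux; on this read-out higher numbers stand for an effect only at larger amounts of compound and lower numbers for an effect already at smaller amounts:

Compound 1, `CCC(=O)N1CC2CC(C1)N2`, gives 490 nM.
Compound 2, `CCCC(=O)N1CC2CC(C1)N2`, gives 580 nM.
Compound 3, `O=C(C1CCC1)N1CC2CC(C1)N2`, gives 2900 nM.

Among the three, compound 3 stands with the highest number: the step of a 5.9-fold higher number from compound 1 to compound 3 (0.77 log units; beyond the scatter) and the step of a 5.0-fold higher number from compound 2 to compound 3 (0.70 log units; beyond the scatter) both lie beyond the scatter, whereas the step of a 1.2-fold higher number from compound 1 to compound 2 (0.07 log units; within the scatter) does not, so the two chain compounds cannot be set in order against each other. Compound 4, `O=C([C@H]1C[C@H]1F)N1CC2CC(C1)N2`, differs from compound 3 in one place: 2-fluorocyclopropyl in place of cyclobutyl on a carbonyl carbon. Within the data shown here, no measured step exchanges one ring for another; the steps that bear on this change are the two in which cyclobutyl enters on the carbonyl carbon, a 5.9-fold higher number from compound 1 to compound 3 (0.77 log units; beyond the scatter) and a 5.0-fold higher number from compound 2 to compound 3 (0.70 log units; beyond the scatter), both modest rises. Taking the cyclobutyl away removes the group that accompanied those rises, but what enters is again a ring rather than a chain, and no measured compound shows how 2-fluorocyclopropyl fares. The account therefore expects only a small step, a 1.9-fold lower number from compound 3 to compound 4 (0.29 log units; within the scatter), small enough to stay within the scatter, with a wide uncertainty on either side. Compound 4 is thus estimated at 1500 nM in this assay, with a range from 400 nM to 5000 nM.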

Compound 4, half-maximal effective concentration: 210 nM
For compound 4 the middle estimate is 7.1-fold (0.85 log units) above the measured one; measured number outside the range, below it.
By their numbers in this assay, from the lowest: compound 4; then compounds 1 and 2 (each within the scatter of the next); then compound 3.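

In this assay, the place on the carbonyl carbon proves able to carry a ring without the higher number seen for compound 3: the step is a 14-fold lower number from compound 3 to compound 4 (1.14 log units; beyond the scatter) and is large, so a ring there does not in itself go with a rise. Compound 4 also lies beyond the scatter below both chain compounds, with a 2.8-fold lower number from compound 2 to compound 4 (0.44 log units; beyond the scatter) and with a 2.3-fold lower number from compound 1 to compound 4 (0.37 log units; beyond the scatter) as well, so the two ring compounds now mark the two ends of the series, compound 4 the lowest number and compound 3 the highest, with the ethyl and propyl compounds in the middle. No measured evidence is at hand to account for this difference between the two rings.

The change swaps a four-membered ring for a three-membered one and brings in fluorine in a single step, so the compounds shown do not tell how much of the step goes with the ring size and how much with the fluorine. As far as these compounds go, whether plain cyclopropyl, cyclopentyl or other stereoisomers of 2-fluorocyclopropyl on the same carbonyl carbon would stand nearer to compound 4 or to compound 3 also stays open.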